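A few compounds are considered here, and "the series" means these few. Any claim that something is new, unique, unknown or untested is made for them only; others in the source may bear on it.

The study examines a small set of dihydrochalcone and chalcone derivatives in an ADME assay on RAW264.7 cells (Mus musculus) for cytotoxicity, read by MTT assay, with a stated time of 24 h, tested at 1.25 ug/mL; on this read-out lower numbers stand for a stronger effect and higher numbers for a weaker effect at the one concentration tested. Compound 1, with the structure `COc1ccc(C(=O)CCc2cccc(OC)c2OC)c(O)c1`, carries a free hydroxyl on the ketone-bearing ring and three methoxy groups in all. In this assay compound 1 gives 96.6%. Compound 2, with the structure `COc1ccc(/C=C/C(=O)c2ccc(OC)c(OC)c2)cc1OC`, has the unsaturated linker and an additional methoxy pattern; in this assay compound 2 gives 94%. The two numbers lie within the scatter of each other, so compound 1 cannot be set apart from compound 2 on this read-out; both sit near the top of the scale, where the effect on the cells is weak.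

Compound 3, with the structure `COc1ccc(C(=O)CCc2ccc(OC)c(OC)c2OC)c(O)c1`, differs from compound 1 by a single change: methoxy in place of hydrogen on an aromatic carbon. Going by the values given here, no step between measured compounds involves this change, so the expectation rests on the two values alone. Both measured compounds leave the cells nearly untouched, and the added methoxy is expected to leave this assay unchanged beyond the scatter, the step from compound 1 to compound 3 being a number 1.6 percentage points lower from compound 1 to compound 3 (within the scatter). For compound 3 a value of 95% is estimated, with a range from 84% to 104%.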

Compound 3, a percentage reported as activity, at one concentration (the size of the read-out at that concentration, not a potency): 101%
The estimate for compound 3 lay 6 percentage points below the measured number, within the range that was stated.
By their numbers in this assay, from the lowest: compounds 2, 1 and 3 (each within the scatter of the next).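

In this assay, methoxy in place of hydrogen on this aromatic carbon, ortho to a methoxy group, meta to a methoxy group and para to a large group, gives a number 4.4 percentage points higher from compound 1 to compound 3 (within the scatter), so compound 1 and compound 3 cannot be told apart on this read-out. Going by these compounds alone, this one-place comparison, which the earlier compounds did not offer, shows that the shared core accepts a methoxy group at this carbon with no measurable gain in cytotoxicity at the one concentration tested, compound 3 giving 101%. No measurement shown here offers an explanation for this result, and none is needed for a step of this size.

The compounds shown leave open whether a different group at this same carbon, such as an amine, a carboxylic acid or a longer chain, would also remain within the scatter of compound 1. They also leave open whether methoxy in place of hydrogen would give a similar result on other aromatic carbons or on the chalcone form with the unsaturated linker, where the cells might respond differently.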